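The source may hold more compounds than are shown below. What is called first, only, known or untested is meant among the compounds shown, and "the series" means these compounds.

Compound 1 `Cc1nn(C)c2c(O)ncnc12` is the shared core on its own, and in an assay on membranes from brain for binding affinity to adenosine receptor A1 (Rattus norvegicus), read by radioligand binding (a lower number here means a stronger inhibitor, a higher number a weaker inhibitor), compound 1 gives 20100 nM. Compound 2 `Cc1nn(C)c2c(O)nc(-c3ccc(Cl)cc3)nc12` carries a chloro-substituted phenyl ring on that core, and in this assay compound 2 gives 410 nM. Going by the values given here, of the two numbers known, compound 2 has the lower one, and the gap to compound 1 lies well beyond the usual scatter of repeated measurements.

Compound 3 `Cc1nn(C)c2c(O)nc(-c3ccc(C(F)(F)F)cc3)nc12` keeps everything in compound 2 except for one exchange: trifluoromethyl in place of chloro on an aromatic carbon. Among the compounds with values here, no measured pair shows this particular exchange, so the size of its effect cannot be read from the data. Since both compounds hold a substituted phenyl ring on the same core, and since the shift from compound 1 to compound 2 already shows that this ring accounts for most of the difference in this assay, the expected step from compound 2 to compound 3 in this assay is small, a 1.6-fold higher number from compound 2 to compound 3 (0.20 log units; within the scatter), at most a mild drift toward a weaker compound and possibly none beyond the scatter. Compound 3 is therefore estimated at 650 nM in this assay, with a range from 200 nM to 2100 nM.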

Compound 3, half-maximal inhibitory concentration: 463 nM
The estimate for compound 3 lay 1.4-fold (0.15 log units) above the measured number; the measured number falls inside the stated range.
By their numbers in this assay, from the lowest: compounds 2 and 3 (each within the scatter of the next); then compound 1.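

In this assay the exchange of chloro for trifluoromethyl on an aromatic carbon, para to a large group, gives a 1.1-fold higher number from compound 2 to compound 3 (0.05 log units; within the scatter) and so leaves the two compounds indistinguishable in this measurement. Going by these compounds alone, the earlier values showed only that compound 2, with its chloro-substituted phenyl ring, has a far lower number than the bare core of compound 1, whereas this pair shows that the substituent at this position can change from one heavy atom to four without a reading beyond the usual scatter. No measured information here explains why the two groups give such closely matched results.

Two groups that match so closely cannot show how much any substituent at this position contributes, and a plain hydrogen in the same place would be needed to show whether chloro and trifluoromethyl help at all. Going by these compounds, whether the tolerance seen here extends to quite different groups on the same carbon, such as an amine, a carboxylic acid or a longer alkyl chain, also remains open.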